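The source may hold more compounds than are shown below. What is called first, only, known or untested is meant among the compounds shown, and "the series" means these compounds.

Series notes, values in an in vitro functional assay on cells for antagonist activity at B1 bradykinin receptor (Homo sapiens), read by luminescence and calcium flux, with a stated time of 2 h; a lower number here means a stronger inhibitor, a higher number a weaker inhibitor:
- compound 1, `Cc1ccc(S(=O)(=O)N2C=CNC(=O)[C@H]2CC(=O)N[C@@H]2CCc3ccccc32)cc1`: 94.7 nM
- compound 2, `Cc1ccc(S(=O)(=O)N2C=CNC(=O)[C@H]2CC(=O)NC2CCCCC2)cc1`: 990 nM

Within the data shown here, compound 2 stands at the higher of the two numbers measured so far; its nearest neighbour is compound 1, and the step of a 10-fold higher number from compound 1 to compound 2 (1.02 log units; beyond the scatter) sets the two apart beyond the scatter. Compound 3, `Cc1ccc(S(=O)(=O)N2C=CNC(=O)[C@H]2CC(=O)NC2CCCCC2C)cc1`, has not yet been measured. It differs from compound 2 by methyl in place of hydrogen on a saturated ring carbon. Among the measured compounds shown here, the one measured step that bears on this change, a 10-fold higher number from compound 1 to compound 2 (1.02 log units; beyond the scatter), concerns the same amide-type nitrogen but exchanges the whole ring for another; no measured step varies a substituent on the cyclohexyl itself. That step shows the group on this nitrogen can shift the number by a large amount, yet it gives no direction for a single added methyl. The expectation for compound 3 is therefore a step within the scatter, a 1.4-fold lower number from compound 2 to compound 3 (0.15 log units; within the scatter), with only a slight lean toward a lower number. Compound 3 is estimated at 700 nM, with a range from 250 nM to 2500 nM.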

Compound 3, half-maximal inhibitory concentration: 25.9 nM
Estimate against measurement, compound 3: 27-fold (1.43 log units) above, and the stated range ends above it.
By their numbers in this assay, from the lowest: compound 3; then compound 1; then compound 2.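

In this assay, one methyl on a saturated ring carbon, next to the ring atom that bears a large group, gives a 38-fold lower number from compound 2 to compound 3 (1.58 log units; beyond the scatter), so this single position on the cyclohexyl can move the number by a large step, which the earlier exchange of one whole ring for another could not show. The 2-methylcyclohexyl group also reverses the order set by that exchange, with a 3.7-fold lower number from compound 1 to compound 3 (0.56 log units; beyond the scatter), so among these three compounds the lowest number belongs to a ring of carbon only on the amide-type nitrogen, not to the 2,3-dihydro-1H-inden-1-yl group. No measurement at hand accounts for the size of the methyl step.

Open, going by these compounds, is whether an ethyl, a methoxy or a hydroxyl at this same ring carbon would lower the number further or give the gain back, and so whether the step is specific to methyl. Also open, on these data alone, is whether the step belongs to one spatial form of the 2-methylcyclohexyl group, as the structure of compound 3 defines none at its two substituted ring carbons.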